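The compounds below may be only part of what the source reports. "The series", "measured", "known", "first", "only" and "open" are said of these compounds alone.

Working notes on a small set of compounds sharing the core of compound 1, tested in an ADME assay on HEK293 cells (Homo sapiens) for inhibition, read by MTT assay, with a stated time of 2 days; a higher number here means a weaker inhibitor, a lower number a stronger inhibitor. Compound 1 `Oc1ccccc1/C=C/c1ccccc1O` gives 24.3 ug/mL. Compound 3 `Oc1ccc(/C=C/c2ccccc2O)cc1` gives 17.5 ug/mL, and the two numbers lie within the scatter of each other. Compound 2 `Nc1cccc(/C=C/c2ccccc2)c1` gives 84 ug/mL, a higher number than compound 1 and beyond the scatter; compound 1 thus sits second highest of the three numbers, nearest to compound 3 and furthest from compound 2. Going by the values given here, no step between compounds that differ in only one place is available within the measured set.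

Compound 4 `Nc1ccccc1/C=C/c1ccccc1O` has not been measured in this assay. It differs from compound 1 by amino in place of hydroxy on an aromatic carbon of a six-membered aromatic ring of carbon only, ortho to a group of 9 heavy atoms; one hydrogen-bond donor and one hydrogen-bond acceptor leave and the same counts enter, with no net charge either way. Among the compounds with values here, the only amino-bearing compound, compound 2, gives 84 ug/mL, but it also lacks a second hydroxy, so it gives no clean read on the exchange. The expected step in this assay is a 1.4-fold higher number from compound 1 to compound 4 (0.16 log units; within the scatter), small and leaning towards a higher number. For compound 4 in this assay the estimate is 35 ug/mL, with a range from 15 ug/mL to 80 ug/mL.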

Compound 4, half-maximal inhibitory concentration: 27 ug/mL
Compound 4: middle estimate off by 1.3-fold (0.11 log units), on the high side; low and high end bracket the measured number.
By their numbers in this assay, from the lowest: compounds 3, 1 and 4 (each within the scatter of the next); then compound 2.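

In this assay, amino in place of hydroxy on an aromatic carbon, ortho to a group of 9 heavy atoms, comes to a 1.1-fold higher number from compound 1 to compound 4 (0.05 log units; within the scatter), so at this place the read-out does not tell the two groups apart. This pair gives the first clean read on the exchange: compound 2 also carries an amino group but differs from compound 1 in more than one place, and what compound 2 gives, 84 ug/mL, cannot be laid on the amino group alone. No measured evidence at hand accounts for this result.

Still open, as far as these compounds go, is whether a methoxy group, a fluorine or a carboxylic acid at this same place would also stay within the scatter of compound 1, or whether the tolerance seen here is limited to amino and hydroxy. Equally open, from the compounds shown here alone, is how the number would respond to amino in place of both hydroxy groups of compound 1, or to a dimethylamino group in place of the amino group of compound 4.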